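Compound 4 in the cytotoxicity series: a step from a limit

The compounds below may be only part of what the source reports. "The series", "measured", "known", "first", "only" and "open" are said of these compounds alone.

In an ADME assay on MT4 cells (Homo sapiens) for cytotoxicity, read by MTT assay, with a stated time of 4 days (on this read-out lower numbers stand for higher toxicity in this test and higher numbers for lower toxicity in this test), compound 1 (`Cc1ccc(OCCn2ccc(=O)n(Cc3ccccc3)c2=O)cc1`) gives 187000 nM and compound 2 (`Cc1ccc(Cn2c(=O)ccn(CCOc3ccc(C)cc3)c2=O)cc1`) gives 250000 nM. Compound 3 (`Cc1ccc(OCCn2ccc(=O)n(Cc3cc(C)ccc3C)c2=O)cc1`) gives > 343000 nM, which is a limit of this assay and not a number. Compound 3 therefore has no exact value from which to count.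

Compound 4 (`Cc1ccc(OCCn2ccc(=O)n(C(C)c3ccccc3)c2=O)cc1`) has not been measured. It carries 1-phenylethyl in place of 2,5-dimethylbenzyl on an aromatic nitrogen.

Three measured steps alter that same group on the shared core. They are a 1.3-fold higher number from compound 1 to compound 2 (0.13 log units; within the scatter), an at least 1.8-fold higher number from compound 1 to compound 3 (0.26 log units; that floor lies within the scatter) and an at least 1.3-fold higher number from compound 2 to compound 3 (0.13 log units; that floor lies within the scatter). All of them lie within the scatter, the last two only as floors. None of compounds 1, 2 and 3 carries 1-phenylethyl, so these steps bear on the change only indirectly.

On this small evidence, no step beyond the scatter is expected in either direction. The expected change is an at least 1.3-fold lower number from compound 3 to compound 4 (0.12 log units; that floor lies within the scatter). For compound 4 the estimated value in this assay is 260000 nM, with an expected range from 130000 nM to 420000 nM.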

Compound 4, half-maximal cytotoxic concentration: 132000 nM
The estimate for compound 4 lay 2.0-fold (0.29 log units) above the measured number; low and high end bracket the measured number.
By their numbers in this assay, from the lowest: compounds 4, 1 and 2 (each within the scatter of the next). At a limit, above all of these: compound 3.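

In this assay, a methyl on the saturated chain carbon bound to the aromatic nitrogen gives no step beyond the scatter, as a 1.4-fold lower number from compound 1 to compound 4 (0.15 log units; within the scatter) shows, and replacing 4-methylbenzyl with 1-phenylethyl likewise stays inside it, with a 1.9-fold lower number from compound 2 to compound 4 (0.28 log units; within the scatter). Going by these compounds alone, the only step at this position printed as beyond the scatter is an at least 2.5-fold lower number from compound 3 to compound 4 (0.41 log units; beyond the scatter), so 1-phenylethyl and 2,5-dimethylbenzyl on this nitrogen are the first pair of groups that the read-out separates, while the exact values of compounds 4, 1 and 2 still sit within the scatter of one another. Compound 3 stands at a limit of the assay and not at a number, so this step is a floor: the limit of > 343000 nM in this assay, at which 1 of the 4 values shown sits.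

As far as these compounds go, how far compound 3 really lies from the other compounds remains open, and with it the true size of that step. Also open, from the compounds shown here alone, is whether a carboxylic acid or an amine on the benzyl aromatic ring, or a longer chain such as 3-phenylpropyl on this nitrogen, would move the number beyond the scatter from compound 1.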